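A few compounds are considered here, and "the series" means these few. Any claim that something is new, unique, unknown or untested is made for them only; others in the source may bear on it.

In an assay on isolated protein for antagonist activity at Bile acid receptor (Homo sapiens), read by HTRF, with a stated time of 30 min (on this read-out higher numbers stand for weaker inhibition and lower numbers for stronger inhibition), compound 1 `CC(C)(C)c1cc(NC(=O)c2c(Cl)cc(N)cc2Cl)ccc1O` gives 5200 nM, and compound 2 `CNc1cc(Cl)c(C(=O)Nc2ccc(O)c(C(C)(C)C)c2)c(Cl)c1` gives 13900 nM, the higher of the two numbers seen so far; the step of a 2.7-fold higher number from compound 1 to compound 2 (0.43 log units; beyond the scatter) was modest but beyond the scatter. Compound 3 `CC(C)(C)c1cc(NC(=O)c2c(Cl)cc(NC3CCCCC3)cc2Cl)ccc1O` differs from compound 2 by cyclohexyl in place of methyl on a nitrogen on an aromatic ring. Among the compounds with values here, only the step from compound 1 to compound 2 bears on this change, and it concerns a smaller group, so the bearing is weak. Compound 3 is therefore expected to stay near compound 2, with a step of a 1.0-fold higher number from compound 2 to compound 3 (0.00 log units; within the scatter) not clearly beyond the scatter. The estimate for compound 3 in this assay is 14000 nM, within 4500 nM to 45000 nM.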

Compound 3, half-maximal inhibitory concentration: 2500 nM
The estimate for compound 3 lay 5.6-fold (0.75 log units) above the measured number; measured number below the stated range.
By their numbers in this assay, from the lowest: compound 3; then compound 1; then compound 2.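

In this assay, this nitrogen on an aromatic ring accepts a much larger group than methyl: cyclohexyl gives a 5.6-fold lower number from compound 2 to compound 3 (0.75 log units; beyond the scatter) and also a 2.1-fold lower number from compound 1 to compound 3 (0.32 log units; beyond the scatter). The effect of substitution here therefore does not follow the direction set by methyl, and compound 3 holds the lowest number of the three, with its steps to both others beyond the scatter. Nothing available explains this reversal.

The compounds shown leave open whether the ring itself matters or only the added carbon. A straight hexyl chain or a phenyl group on this nitrogen would bear on that question.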